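The compounds below may be only part of what the source reports. "The series", "measured", "known", "first", "only" and "open" are said of these compounds alone.

Of the compounds shown here, three built on one shared core have been measured in an assay on CHO cells for displacement of a labelled ligand from adenosine receptor A1 (Homo sapiens), read by scintillation counting, with a stated time of 90 min; on this read-out higher numbers stand for weaker inhibition and lower numbers for stronger inhibition. Compound 1 `COc1cccc(CNc2nc(N)c3nc(-c4ccc(C)o4)sc3n2)c1` gives 70 nM in this assay. Compound 2 `Nc1nc(NCc2ccncc2)nc2sc(-c3ccco3)nc12` gives 47 nM. Compound 3 `COc1cccc(CNc2nc(N)c3nc(-c4cccs4)sc3n2)c1` gives 37 nM, which is the lowest of the three numbers, though both other values lie within the scatter of it: compound 2 sits close to it, and the step of a 1.9-fold lower number from compound 1 to compound 3 (0.28 log units; within the scatter) is also within the scatter. Within the data shown here, that step exchanges one five-membered ring for another on the core and is the only one-place step among the measured compounds.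

Compound 4 `COc1ccccc1CNc1nc(N)c2nc(-c3cccs3)sc2n1` has not yet been measured in this assay. It differs from compound 3 by 2-methoxyphenyl in place of 3-methoxyphenyl on a saturated chain carbon bound to a nitrogen on an aromatic ring, the two compounds having the same atoms joined differently. Among the measured compounds shown here, none of the measured steps touches the methoxyphenyl group, so nothing among the measured compounds shows how this change acts in this assay. On that ground no step beyond the scatter is expected, and the expected step of a 1.4-fold higher number from compound 3 to compound 4 (0.13 log units; within the scatter) is set close to no change, with a wide range to reflect the missing precedent. Compound 4 is therefore expected to give 50 nM in this assay, between 15 nM and 200 nM.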

Compound 4, inhibition constant: 17.3 nM
Beside the measured number, compound 4's estimate is 2.9-fold (0.46 log units) above it, within the range that was stated.
By their numbers in this assay, from the lowest: compound 4; then compounds 3, 2 and 1 (each within the scatter of the next).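

Among these compounds, the exchange of 3-methoxyphenyl for 2-methoxyphenyl, on a saturated chain carbon bound to a nitrogen on an aromatic ring, is the first measured change at this group, and in this assay it gives a 2.1-fold lower number from compound 3 to compound 4 (0.33 log units; beyond the scatter), a modest step that lies just beyond the scatter. Among the compounds shown here, the two compounds have the same atoms, joined differently, so this result shows that the number responds to where the methoxy group sits on the phenyl ring, whereas the only earlier one-place step, a 1.9-fold lower number from compound 1 to compound 3 (0.28 log units; within the scatter), changed a different part of the molecule and stayed within the scatter. Nothing at hand explains this step, and with a single pair it remains one observation rather than a pattern.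

The compounds shown leave open whether the same exchange would have a similar effect with the 5-methylfuran-2-yl group of compound 1 on the shared core in place of thiophen-2-yl. They also leave open how a 4-methoxyphenyl group, an unsubstituted phenyl ring or a 2-ethoxyphenyl group would compare at the same place.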